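Swapping a flexible amine for a piperidine ring

A few compounds are considered here, and "the series" means these few. Any claim that something is new, unique, unknown or untested is made for them only; others in the source may bear on it.

Of the compounds shown here, three sharing one core have been measured in an assay on HEK293 cells for inhibition of Steryl-sulfatase (Homo sapiens), tested at 1 uM; a lower number here means a weaker effect, a higher number a stronger effect of the compound at the concentration tested. Compound 1, `CN(C)CCN(CCN(C)C)c1cccc(C(=O)N2CCc3ccc(OS(N)(=O)=O)cc3C2)c1`, gives 17.1%, the lowest of the three numbers. Compound 2, `NS(=O)(=O)Oc1ccc2c(c1)CN(C(=O)c1cccc(N3CCN(c4ncccn4)CC3)c1)CC2`, gives 24.4%, which lies within the usual scatter of compound 1. Compound 3, `CN(C)CCCN(Cc1ccccc1)c1ccc(C(=O)N2CCc3ccc(OS(N)(=O)=O)cc3C2)cc1`, gives 61.6%, a number clearly beyond the scatter above compound 1.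

The unmeasured compound 4, `NS(=O)(=O)Oc1ccc2c(c1)CN(C(=O)c1cccc(N3CCCCC3)c1)CC2`, differs from compound 1 in a single place: piperidin-1-yl in place of bis(2-(dimethylamino)ethyl)amino on an aromatic carbon. The new group sits on an aromatic carbon of a six-membered aromatic ring of carbon only, meta to a large group. Among the compounds with values here, no step between measured compounds matches this exact change, so the expectation rests on the overall picture. Compound 2 also carries a six-membered nitrogen ring at the same place and gives 24.4%, so a similar, modest read-out seems plausible. The step of a number 6.9 percentage points higher from compound 1 to compound 4 (within the scatter) is therefore expected to be small and not clearly beyond the scatter. For compound 4 in this assay, the estimate is 24%, with a range from 8% to 42%.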

Compound 4, a percentage reported as inhibition, at one concentration (the size of the read-out at that concentration, not a potency): 11.9%
Compound 4: the middle estimate sits 12.1 percentage points above what was measured, within the range that was stated.
By their numbers in this assay, from the lowest: compounds 4, 1 and 2 (each within the scatter of the next, the first and the last beyond it); then compound 3.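

Exchanging bis(2-(dimethylamino)ethyl)amino for piperidin-1-yl on this aromatic carbon replaces an open group of 11 heavy atoms with a ring of 6 and gives a number 5.2 percentage points lower from compound 1 to compound 4 (within the scatter) in this assay at this concentration. At this position, the read-out therefore does not separate the large open group with its 3 nitrogen atoms from the smaller ring with its single nitrogen, and both compounds stay modest. Nothing measured here offers an explanation for this result.

On these data alone, whether a morpholine ring, a dimethylamino group or a piperidine ring carrying a carboxylic acid would move the read-out at this place remains open. A read-out at one concentration is also not a potency, so any smaller difference between these two compounds could remain hidden.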